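A few compounds are considered here, and "the series" means these few. Any claim that something is new, unique, unknown or untested is made for them only; others in the source may bear on it.

Compound 2 `CCC1CC=C(c2nc(C(F)(F)F)ccc2CNC(=O)C(C)c2ccc(NS(C)(=O)=O)c(F)c2)CC1` gives the lower of the two numbers in an assay on CHO cells for antagonist activity at transient receptor potential cation channel subfamily V member 1 (Homo sapiens), read by FLIPR and calcium flux (on this read-out lower numbers stand for stronger inhibition and higher numbers for weaker inhibition), at 0.1 nM; compound 1 `CC(C(=O)NCc1ccc(C(F)(F)F)nc1CCC(C)(C)C)c1ccc(NS(C)(=O)=O)c(F)c1` gives 0.6 nM, and the step of a 6.0-fold lower number from compound 1 to compound 2 (0.78 log units; beyond the scatter) came from a change at the same aromatic carbon. Compound 3 `CCC/C=C\c1nc(C(F)(F)F)ccc1CNC(=O)C(C)c1ccc(NS(C)(=O)=O)c(F)c1` carries pent-1-en-1-yl in place of 4-ethylcyclohex-1-en-1-yl on an aromatic carbon. Going by the values given here, only that one step bears on the new change, and it concerned a different entering group, so it offers a loose guide. Compound 3 is expected to give 0.4 nM in this assay, within 0.1 nM to 1.5 nM. The expected step of a 4.0-fold higher number from compound 2 to compound 3 (0.60 log units; beyond the scatter) is a modest move toward a higher number.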

Compound 3, inhibition constant: 2.1 nM
For compound 3 the middle estimate is 5.3-fold (0.72 log units) below the measured one; the measured number lies above the stated range.
By their numbers in this assay, from the lowest: compound 2; then compound 1; then compound 3.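

Replacing the 4-ethylcyclohex-1-en-1-yl ring with the open pent-1-en-1-yl chain gives a 21-fold higher number from compound 2 to compound 3 (1.32 log units; beyond the scatter) in this assay, so the double bond, present in both groups, is not enough on its own to keep the low number of compound 2 at this position. The new chain also does worse than the saturated 3,3-dimethylbutyl group, with a 3.5-fold higher number from compound 1 to compound 3 (0.54 log units; beyond the scatter), so a double bond here does not by itself give a lower number.

The ring and the carbon count change together in this swap, and a plain cyclohexyl or a phenyl group could help separate the two. Nothing measured here explains these shifts.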